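Nitro in Place of Chloro on a Shared Core

The source may hold more compounds than are shown below. What is called first, only, known or untested is meant among the compounds shown, and "the series" means these compounds.

Compound 1, `CC(=O)N1N=C(c2ccc3ccccc3c2)OC1c1ccccc1Br`: 6.98 ug/mL
Compound 2, `CC(=O)N1N=C(c2ccc3ccccc3c2)OC1c1ccc(Cl)cc1`: 2.48 ug/mL

Of the compounds shown here, two have been measured in a functional assay on B16-F10 cells (Mus musculus) for antiproliferative activity, read by MTT assay, with a stated time of 48 h; a higher number here means a weaker inhibitor, a lower number a stronger inhibitor. Compound 1 gives 6.98 ug/mL, and compound 2 gives 2.48 ug/mL, the lowest of the two numbers; the step of a 2.8-fold lower number from compound 1 to compound 2 (0.45 log units; beyond the scatter) is modest. Compound 3, `CC(=O)N1N=C(c2ccc3ccccc3c2)OC1c1ccc([N+](=O)[O-])cc1`, differs from compound 2 by nitro in place of chloro on an aromatic carbon. Among the compounds with values here, no measured step exchanges a chloro for a nitro, so the single known step gives no direct guide here. Compound 3 is therefore expected to stay close to compound 2, with a step of a 1.2-fold higher number from compound 2 to compound 3 (0.08 log units; within the scatter) that lies within the scatter. The estimate for compound 3 is 3 ug/mL, ranging from 1 ug/mL to 9 ug/mL.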

Compound 3, half-maximal inhibitory concentration: 9.32 ug/mL
The estimate for compound 3 lay 3.1-fold (0.49 log units) below the measured number; measured number outside the range, above it.
By their numbers in this assay, from the lowest: compound 2; then compounds 1 and 3 (each within the scatter of the next).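

At this aromatic carbon the group matters: nitro in place of chloro gives a 3.8-fold higher number from compound 2 to compound 3 (0.57 log units; beyond the scatter), a step beyond the scatter. Moving to the 4-nitrophenyl group from the 2-bromophenyl group gives a 1.3-fold higher number from compound 1 to compound 3 (0.13 log units; within the scatter), which is within the scatter, so of these three compounds only compound 2, with its 4-chlorophenyl group, stands apart. No data here explain why nitro and chloro differ. Still open, going by these compounds, is whether a fluoro, a methoxy, an amine or a carboxylic acid on this same carbon would fall nearer compound 2 or compound 3.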